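This account rests on a few compounds, and the source may have more. Where it says the series, first, only, none or still open, it means among the compounds named here.

Compound 1 `COc1cc(OC)c(/C=C/S(=O)(=O)Cc2ccc(OC)c(N)c2)c(OC)c1` — 80 nM
Compound 2 `COc1cc(/C=C/S(=O)(=O)Cc2ccc(OC)c([N+](=O)[O-])c2)cc(OC)c1` — > 30000 nM

In an ADME assay on MRC5 cells (Homo sapiens) for cytotoxicity, read by MTT assay, with a stated time of 72 h (a lower number here means a stronger inhibitor of growth, a higher number a weaker inhibitor of growth), compound 1 gives 80 nM. For compound 2 only a limit is recorded in this assay, namely > 30000 nM, which is a limit of the measurement and not a number. Compound 2 therefore stands at the limit of > 30000 nM in this assay, at which 1 of the 2 values shown sits. Compound 3 `COc1cc(/C=C/S(=O)(=O)Cc2ccc(OC)c(N)c2)cc(OC)c1` is not yet measured; it differs from compound 2 by amino in place of nitro on an aromatic carbon. Compound 1 also carries an amino group, but it differs from compound 3 elsewhere as well. The step from compound 2 to compound 3 is expected to be large, toward stronger inhibition, an at least 50-fold lower number from compound 2 to compound 3 (1.69 log units; beyond the scatter). Compound 3 is expected to give 600 nM in this assay, in a range from 60 nM to 10000 nM.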

Compound 3, concentration for 50% growth inhibition: > 30000 nM
Compound 3: only a limit was reported; the forecaster's own chance of this, stated with the estimate: 25%; middle value at least 50-fold (1.69 log units) away from the limit.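

No step can be read from compound 2 to compound 3, since both values are limits and not numbers: the limit of > 30000 nM in this assay, at which 2 of the 3 values shown sit.

The compounds shown leave open how much amino in place of nitro on an aromatic carbon changes growth inhibition, and which structural difference separates compound 1 from compound 3.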